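Piperidine for Dimethylamine, One Bond Further Out

A few compounds are considered here, and "the series" means these few. Any claim that something is new, unique, unknown or untested is made for them only; others in the source may bear on it.

Of the compounds shown here, three on a shared core have been measured in a physicochemical assay for lipophilicity, using the shake flask method, measured as octanol-water partition, at pH 7.4; a higher number here means a more lipophilic compound, a lower number a more polar compound. Compound 1 `COc1cc(/C=C/C(=O)Nc2ccccc2)ccc1OCCCCN(C)C` gives 1.57 in this assay. Compound 2 `COc1cc(/C=C/C(=O)Nc2ccccc2)ccc1OCCCCN1CCCCC1` carries, relative to compound 1, (piperidin-1-yl in place of dimethylamino on a saturated chain carbon, four bonds along the chain from an oxygen on an aromatic ring); in this assay compound 2 gives 1.61. Compound 3 `COc1cc(/C=C/C(=O)Nc2ccccc2)ccc1OCCCCCN(C)C` differs from compound 1 by (dimethylamino)methyl in place of dimethylamino on a saturated chain carbon, four bonds along the chain from an oxygen on an aromatic ring; in this assay compound 3 gives 1.61. The steps of a number 0.04 log units higher from compound 1 to compound 2 (within the scatter), a number 0.04 log units higher from compound 1 to compound 3 (within the scatter) and no change at the digits printed from compound 2 to compound 3 (within the scatter) are all within the scatter, so no ordering among the three can be read from them.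

Compound 4 `COc1cc(/C=C/C(=O)Nc2ccccc2)ccc1OCCCCCN1CCCCC1` has not yet been measured. It differs from compound 3 by piperidin-1-yl in place of dimethylamino on a saturated chain carbon, five bonds along the chain from an oxygen on an aromatic ring. This is the same kind of change as that from compound 1 to compound 2, but not the same: there the place was on a saturated chain carbon, four bonds along the chain from an oxygen on an aromatic ring, whereas here it is five bonds along the chain. The earlier step, a number 0.04 log units higher from compound 1 to compound 2 (within the scatter), stayed within the scatter. Because compound 3 gives 1.61, compound 4 is expected near 1.65. The expected step is a number 0.04 log units higher from compound 3 to compound 4 (within the scatter). The estimate for compound 4 is expected to lie between 1.35 and 1.95.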

Compound 4, partition coefficient: 1.65
Beside the measured number, compound 4's estimate shows no gap at the digits printed; low and high end bracket the measured number.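

In this assay, piperidin-1-yl in place of dimethylamino, five bonds along the chain from an oxygen on an aromatic ring, gives a number 0.04 log units higher from compound 3 to compound 4 (within the scatter), and the same change at four bonds along the chain gives a number 0.04 log units higher from compound 1 to compound 2 (within the scatter), so on both cores the step stays within the scatter and is printed at the same size. The other new steps, a number 0.04 log units higher from compound 2 to compound 4 (within the scatter) and a number 0.08 log units higher from compound 1 to compound 4 (within the scatter), also stay within the scatter, so the agreement shows that the change carried across these two cores without a step beyond the scatter, but it gives the change no real size or direction and no ordering of the four compounds. Nothing among the data offered accounts for the result.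

The compounds shown leave open whether this would hold for morpholin-4-yl or 4-methylpiperazin-1-yl in place of piperidin-1-yl. They also leave open what either amine would give on a longer chain, since only these two chains appear here.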